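Replacing phenyl with 1H-1,2,3-triazol-4-yl on a carbonyl carbon

This account rests on a few compounds, and the source may have more. Where it says the series, first, only, none or still open, it means among the compounds named here.

Measured so far:
compound 1 `O=C(c1ccccc1)N1CCC(C(=O)N2N=CCC2c2ccccc2)CC1` gives 4.4
compound 2 `O=C(c1cscn1)N1CCC(C(=O)N2N=CC[C@H]2c2ccccc2)CC1` gives 3

Both numbers come from a physicochemical assay for lipophilicity, read by HPLC, measured as chromatographic lipophilicity, at pH 7.4 (on this read-out lower numbers stand for lower lipophilicity and higher numbers for higher lipophilicity), and are the only two available. Compound 1 holds the higher number, and compound 2 lies below it by a gap beyond the usual scatter of repeated measurements. Within the data shown here, no two measured compounds differ in just one place, so the data offer no clean single step to lean on.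

The compound still to be measured, compound 3 `O=C(c1c[nH]nn1)N1CCC(C(=O)N2N=CCC2c2ccccc2)CC1`, keeps the core of compound 1 and changes one group: 1H-1,2,3-triazol-4-yl in place of phenyl on a carbonyl carbon. In words, 1H-1,2,3-triazol-4-yl stands in place of phenyl on a carbonyl carbon, so benzoyl becomes (1H-1,2,3-triazol-4-yl)carbonyl.

Among the measured compounds shown here, the only guide is compound 2, which also has something other than phenyl on that carbonyl carbon and gives 3 in this assay. A downward step beyond the scatter is therefore expected. The estimated step is a number 1.80 log units lower from compound 1 to compound 3 (beyond the scatter), though it rests on very little evidence. For compound 3 the estimate is 2.6, with an expected range from 2 to 3.2.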

Compound 3, distribution coefficient: 2
Compound 3: middle estimate off by 0.60 log units, on the high side; measured number inside the range.
By their numbers in this assay, from the lowest: compound 3; then compound 2; then compound 1.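

In this assay, among these compounds, this is the first step between two compounds that differ in one place only: putting 1H-1,2,3-triazol-4-yl in place of phenyl on a carbonyl carbon gives a number 2.40 log units lower from compound 1 to compound 3 (beyond the scatter). With the rest of the molecule unchanged, the read-out clearly depends on which ring sits at this position, and this single exchange produces a large step. The exchange alters several things at once, including ring size, ring atoms and hydrogen-bond donor and acceptor counts, and nothing available here separates their contributions or explains the step.

On these data alone, what remains open is how much of the step belongs to this particular ring, since a single exchange cannot show how other groups would behave on the same carbonyl carbon; a pyridine ring, a methyl-substituted 1,2,3-triazole or a carboxylic acid there would each test a different part of the change. As far as these compounds go, it is also open whether the same exchange would give a step of similar size on a different core.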